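The source may report more compounds than this note shows. Statements on the series, on what has been measured and on what is new or still open speak of the compounds shown alone.

Compound 1 `COc1ccc(C2=NN(C3=NC(=O)/C(=C4\C(=O)Nc5ccc(Br)cc54)S3)C(c3ccc(OC)cc3)C2)cc1`: 430 nM
Compound 2 `COc1ccc(C2CC(c3ccc4ccccc4c3)=NN2C2=NC(=O)/C(=C3\C(=O)Nc4ccc(Br)cc43)S2)cc1`: 220 nM
Compound 3 `COc1ccc(C2=NN(C3=NC(=O)/C(=C4\C(=O)Nc5ccccc54)S3)C(c3ccc(Cl)cc3)C2)cc1`: 100000 nM

All three were tested in a functional assay on cells (Cancer cell lines, Homo sapiens) for cytotoxicity, read by sulforhodamine B assay, with a stated time of 48 h; a lower number here means a stronger inhibitor of growth, a higher number a weaker inhibitor of growth. In this assay compound 1 gives 430 nM, compound 2 gives 220 nM and compound 3 gives 100000 nM. From compound 1 to compound 2 the change is naphthalen-2-yl in place of 4-methoxyphenyl on a carbon with a double bond to nitrogen, and the step was a 2.0-fold lower number from compound 1 to compound 2 (0.29 log units; within the scatter). Compound 3 sits far from both of the others, and how its core differs from the core of compound 1 is not broken down here. Compound 4 `O=C1N=C(N2N=C(c3ccc4ccccc4c3)CC2c2ccc(Cl)cc2)S/C1=C1/C(=O)Nc2ccccc21` has not been measured; it arises from compound 3 by naphthalen-2-yl in place of 4-methoxyphenyl on a carbon with a double bond to nitrogen. Among the compounds with values here, this is the same kind of change as the one from compound 1 to compound 2, though here the ring atom two ring bonds away bears a 4-chlorophenyl group rather than a 4-methoxyphenyl group. Because the earlier step of a 2.0-fold lower number from compound 1 to compound 2 (0.29 log units; within the scatter) stayed within the scatter, little movement is expected for compound 4, whose expected step is a 1.7-fold lower number from compound 3 to compound 4 (0.22 log units; within the scatter). Compound 4 is estimated at 60000 nM, most likely between 15000 nM and 150000 nM.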

Compound 4, concentration for total growth inhibition: 20900 nM
Compound 4: the middle estimate sits 2.9-fold (0.46 log units) above what was measured; low and high end bracket the measured number.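

In this assay, naphthalen-2-yl in place of 4-methoxyphenyl gave a 4.8-fold lower number from compound 3 to compound 4 (0.68 log units; beyond the scatter) and can now be set beside the same change on the other core: the same change on two cores in this assay, a 2.0-fold lower number (0.29 log units; within the scatter) from compound 1 to compound 2 and a 4.8-fold lower number (0.68 log units; beyond the scatter) from compound 3 to compound 4, 2.4-fold (0.39 log units) apart, within the scatter of two such steps. The two steps therefore do not differ measurably, which fits the change carrying over between these two cores. Within the data shown here, this does not show a fixed size for the step or any transfer to further cores, and only the step on the core of compound 3 lies beyond the scatter.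

Still open, on these data alone, is how a phenyl or thiophene ring would behave in this place, or an amine or carboxylic acid on the naphthalene. No pair shown differs in one place between the cores of compound 1 and compound 3, so what separates their values also stays open.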